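Methyl in place of hydrogen on a phenol oxygen

This account rests on a few compounds, and the source may have more. Where it says the series, first, only, none or still open, it means among the compounds named here.

Measured so far:
compound 1, `Cn1cc(/C=C2\C(=O)Nc3ccc(S(N)(=O)=O)cc32)c2ccccc21`: 103%
compound 2, `CN(C)S(=O)(=O)c1ccc2c(c1)/C(=C/c1cn(C)c3ccc(O)cc13)C(=O)N2`: 96%

Of the compounds shown here, two sharing one core have been tested in an assay on isolated protein for inhibition of homeodomain-interacting protein kinase 2 (Homo sapiens), tested at 1 uM; on this read-out lower numbers stand for a stronger effect and higher numbers for a weaker effect at the one concentration tested. Compound 2 gives the lower of the two numbers, 96%, while compound 1 gives 103%. The gap between them lies within the usual scatter of this assay, so nothing can be said about which of the two acts more strongly; both read-outs sit near the level that means little effect at the one concentration tested.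

Compound 3, `COc1ccc2c(c1)c(/C=C1\C(=O)Nc3ccc(S(=O)(=O)N(C)C)cc31)cn2C`, has not been measured yet. Compared with compound 2, the change is methyl in place of hydrogen on an oxygen on an aromatic ring. Among the measured compounds shown here, no step between measured compounds is available to guide a forecast, and the two values seen so far give no hint of movement in either direction. The step from compound 2 to compound 3 is therefore expected to be small, a number 2 percentage points higher from compound 2 to compound 3 (within the scatter), not beyond the scatter. For compound 3 the expected read-out in this assay is 98%, in the range 85% to 110%.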

Compound 3, a percentage reported as activity, at one concentration (the size of the read-out at that concentration, not a potency): 85%
Compound 3: middle estimate off by 13 percentage points, on the high side; measured number inside the range.
By their numbers in this assay, from the lowest: compound 3; then compounds 2 and 1 (each within the scatter of the next).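

Among the compounds shown here, the swap from hydroxy to methoxy gives a number 11 percentage points lower from compound 2 to compound 3 (beyond the scatter) in this assay and is the only step so far that can be read at all. It shows that the oxygen on this aromatic ring is a place where a single added methyl can move the read-out, towards a stronger effect at the one concentration tested, although the move is modest. No measurement at hand accounts for the shift.

One pair cannot say whether a longer chain on this oxygen, such as ethoxy or propoxy, would move the number further or reverse the step. Nor can it say how an amine or a fluorine in place of the methoxy group would read.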